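Series notes: ester in place of pyrazole on the shared core

The source may hold more compounds than are shown below. What is called first, only, known or untested is meant among the compounds shown, and "the series" means these compounds.

Of the compounds shown here, three share one core and have been measured in a functional assay on MCF7 cells (Homo sapiens) for inhibition, read by CCK-8 assay, with a stated time of 48 h; on this read-out lower numbers stand for stronger inhibition and higher numbers for weaker inhibition. Compound 1 `COc1ccc(-c2cc3nccc(-c4cc(OC)c(OC)c(OC)c4)n3n2)cc1F` gives 183 nM. Compound 2 `COc1cc(-c2ccnc3cc(-c4ccc(-c5cnn(C)c5)cc4)nn23)cc(OC)c1OC` gives 274 nM, and compound 3 `COc1cc(-c2ccnc3cc(-c4ccc5cnn(C)c5c4)nn23)cc(OC)c1OC` gives 279 nM. Compound 2 stands second highest of the three numbers, yet its gaps to both neighbours lie within the scatter, so no order among the three can be claimed. For the measured compounds named here, the only single-point step on record, a 1.5-fold higher number from compound 1 to compound 3 (0.18 log units; within the scatter), is likewise within the scatter.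

Compound 4 `CCOC(=O)c1ccc(-c2cc3nccc(-c4cc(OC)c(OC)c(OC)c4)n3n2)cc1` has not been measured. Its change from compound 2 is ethoxycarbonyl in place of 1-methyl-1H-pyrazol-4-yl on an aromatic carbon. Going by the values given here, no measured step swaps a five-membered aromatic group for an open-chain ester, so nothing on record bears directly on this change; the one step available, from compound 1 to compound 3, only shows that exchanging groups at this position of the shared core has so far moved the number little. On that basis the step expected in this assay is a 1.2-fold higher number from compound 2 to compound 4 (0.07 log units; within the scatter), that is, no movement beyond the scatter, with the range widened to reflect the lack of a direct precedent. Compound 4 is accordingly estimated at 320 nM, with a range from 100 nM to 1000 nM.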

Compound 4, half-maximal inhibitory concentration: > 10000 nM
Compound 4 gave a limit, no number (the forecaster's own chance of this, stated with the estimate: 5%); middle value at least 31-fold (1.49 log units) away from the limit.
By their numbers in this assay, from the lowest: compounds 1, 2 and 3 (each within the scatter of the next). At a limit, above all of these: compound 4.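

Compound 4 reads as a limit of the assay and not a number: the limit of > 10000 nM in this assay, at which 1 of the 4 values shown sits. In this assay, the change shows an at least 36-fold higher number from compound 2 to compound 4 (1.56 log units; beyond the scatter), whereas the earlier exchange of groups on the shared core, a 1.5-fold higher number from compound 1 to compound 3 (0.18 log units; within the scatter), gave no sign that the read-out could move this far. The group para to a large group on the six-membered aromatic ring of carbon only can therefore decide the read-out, even though 1-methyl-1H-pyrazol-4-yl and ethoxycarbonyl match in their counts of hydrogen-bond donors and acceptors, so those counts do not separate the two groups.

This single change removes a five-membered aromatic ring and brings in an open-chain ester with a double bond outside aromatic rings, and the compounds shown cannot say which of these differences goes with the result, or whether the ester itself or merely the loss of the ring matters. A carboxylic acid, a primary amide or a small five-membered aromatic ring without a methyl group at the same place would help to separate these readings, and the limit leaves the true size of the step open.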